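Working notes: aromatic group swap from compound 3 to compound 4

The compounds below may be only part of what the source reports. "The series", "measured", "known", "first", "only" and "open" are said of these compounds alone.

In an ADME assay on A549 cells (Homo sapiens) for cytotoxicity, read by resazurin assay, with a stated time of 48 h (a lower number here means that less compound is tolerated, a higher number that more compound is tolerated), compound 3 (`O=C(Nc1ccc(NCc2cccc(C(F)(F)F)c2)cc1Cl)c1cc(Cl)ccc1O`) gives 13300 nM. Compound 2 (`O=C(Nc1ccc(NCc2ccccc2)cc1Cl)c1cc(Cl)ccc1O`) gives 19700 nM, within the scatter of that number, whereas compound 1 (`CC1(Nc2ccc(NC(=O)c3cc(Cl)ccc3O)c(Cl)c2)CCCC1`) gives 157000 nM, beyond the scatter of both.

The next compound to be tested, compound 4 (`O=C(Nc1ccc(NCc2cc(Cl)cc(Cl)c2)cc1Cl)c1cc(Cl)ccc1O`), carries 3,5-dichlorophenyl in place of 3-(trifluoromethyl)phenyl on a saturated chain carbon bound to a nitrogen on an aromatic ring.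

Among the compounds with values here, two measured steps bear on this change. The larger one, benzyl in place of 1-methylcyclopentyl on a nitrogen on an aromatic ring, is an 8.0-fold lower number from compound 1 to compound 2 (0.90 log units; beyond the scatter). It replaces the whole group, while the present change keeps a six-membered aromatic ring of carbon only, so it is a weak guide. The closer one, trifluoromethyl in place of hydrogen on an aromatic carbon, is a 1.5-fold lower number from compound 2 to compound 3 (0.17 log units; within the scatter), and on that evidence no step beyond the scatter is expected in this assay. From the compounds shown here alone, the series holds no measured comparison of the two aromatic groups themselves, so the direction remains open.

The estimated step is a 1.1-fold lower number from compound 3 to compound 4 (0.04 log units; within the scatter).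

Compound 4 is expected at 12000 nM, with an estimated range of 6000 nM to 24000 nM.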

Compound 4, half-maximal cytotoxic concentration: 13300 nM
Beside the measured number, compound 4's estimate is 1.1-fold (0.04 log units) below it, and the stated range covers the measured number.
By their numbers in this assay, from the lowest: compounds 3, 4 and 2 (each within the scatter of the next); then compound 1.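

In this assay, within the data shown here, 3,5-dichlorophenyl in place of 3-(trifluoromethyl)phenyl on a saturated chain carbon bound to a nitrogen on an aromatic ring gives no change at the digits printed from compound 3 to compound 4 (within the scatter), the first direct comparison of two substituted aromatic groups at this position. Measured against the unsubstituted phenyl, the same group gives a 1.5-fold lower number from compound 2 to compound 4 (0.17 log units; within the scatter), so a second substitution pattern also produces no step beyond the scatter, and compounds 2, 3 and 4 form one group in this assay, while a 12-fold lower number from compound 1 to compound 4 (1.07 log units; beyond the scatter) shows that compound 1 alone stands apart. No measurement at hand accounts for these aromatic groups reading alike.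

The compounds shown leave open whether an amine or a carboxylic acid on the aromatic ring would also stay within the scatter of compound 2, since only chlorine and trifluoromethyl appear there so far. They also leave open whether a longer chain in place of the single saturated carbon bound to the nitrogen would keep the number within that same group or shift it.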